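This account rests on a few compounds, and the source may have more. Where it says the series, first, only, none or still open, it means among the compounds named here.

Compound 1 `CNC(=O)c1cnc(N2CCN(C3CCN(Cc4ccc(Cl)cc4)CC3)[C@@H](C)C2)c(Cl)c1` gives 32 nM in a functional assay for antagonist activity at C-X-C chemokine receptor type 3 (Homo sapiens); a lower number here means a stronger inhibitor, a higher number a weaker inhibitor. Among the compounds with values here, compound 2 `CNC(=O)c1cnc(N2CCN(C3CCN(Cc4ccco4)CC3)[C@@H](C)C2)c(Cl)c1` gives 8100 nM in this assay, and this is the higher of the two numbers measured so far: its nearest neighbour is compound 1, and the step of a 250-fold higher number from compound 1 to compound 2 (2.40 log units; beyond the scatter) is the only measured change, made by putting furan-2-yl in place of 4-chlorophenyl on a saturated chain carbon bound to an amine nitrogen in a ring.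

Compound 3 `CNC(=O)c1cnc(N2CCN(C3CCN(Cc4cccs4)CC3)[C@@H](C)C2)c(Cl)c1` has not yet been measured. It differs from compound 2 at the same position: thiophen-2-yl in place of furan-2-yl on a saturated chain carbon bound to an amine nitrogen in a ring. Within the data shown here, the one measured step that bears on this place, a 250-fold higher number from compound 1 to compound 2 (2.40 log units; beyond the scatter), was large, but it exchanged a six-membered ring carrying a chlorine for a five-membered ring with one hetero atom. The move from compound 2 to compound 3 keeps a five-membered aromatic ring with one hetero atom and changes only which hetero atom it is, so a much smaller step is expected, possibly none beyond the scatter. The expected step for compound 3 is a 2.0-fold lower number from compound 2 to compound 3 (0.31 log units; beyond the scatter), giving an estimate for compound 3 of 4000 nM, between 1000 nM and 16000 nM.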

Compound 3, half-maximal inhibitory concentration: 1980 nM
The estimate for compound 3 lay 2.0-fold (0.31 log units) above the measured number, within the range that was stated.
By their numbers in this assay, from the lowest: compound 1; then compound 3; then compound 2.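

In this assay the exchange of oxygen for sulfur within a five-membered aromatic ring, with the same count of heavy atoms, still gives a 4.1-fold lower number from compound 2 to compound 3 (0.61 log units; beyond the scatter) and so shows that this position tells these two rings apart, not only six-membered rings from five-membered ones. Thiophen-2-yl wins back only part of the loss: a 62-fold higher number from compound 1 to compound 3 (1.79 log units; beyond the scatter) still remains and leaves 4-chlorophenyl well ahead of both five-membered rings at this place. No supporting measurement is available to explain either step.

Compound 1 differs from compound 2 and compound 3 both in ring size and in carrying a chlorine, so these compounds cannot separate the two changes, and a plain phenyl group would be the direct test. They also leave open how a pyridine ring, or a thiophen-2-yl ring carrying a chlorine, would behave on a saturated chain carbon bound to an amine nitrogen in a ring.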